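This account rests on a few compounds, and the source may have more. Where it says the series, first, only, none or still open, it means among the compounds named here.

Half-lives measured so far in an ADME assay on microsomes from liver (Homo sapiens) for metabolic stability, read by LC-MS, using NADPH, with a stated time of 10 min, tested at 10 uM; a higher number here means that the compound lasts longer, a lower number that the compound disappears faster

- Compound 1 (`N#Cc1ccnc(Oc2nn(C3CCC3)c3ncnc(N)c23)c1`) gives 2.35 h
- Compound 2 (`Nc1ncnc2c1c(Oc1cc(C(F)(F)F)ccn1)nn2C1CC1`) gives > 2.41 h as a limit, not a number
- Compound 3 (`Nc1ncnc2c1c(Oc1cc(C(F)(F)F)ccn1)nn2[C@H]1CC[C@@H](CO)CC1`) gives 1.6 h

Compound 2 has only the limit of > 2.41 h in this assay, at which 1 of the 3 values shown sits, and no exact half-life in the data. Compound 4 (`Nc1ncnc2c1c(Oc1cc(C(F)(F)F)ccn1)nn2[C@H]1CC[C@H](CO)CC1`) keeps the core of compound 2 but has 4-(hydroxymethyl)cyclohexyl in place of cyclopropyl on an aromatic nitrogen. For the measured compounds named here, one measured step bears on this change: an at least 1.5-fold lower number from compound 2 to compound 3 (0.17 log units; that floor lies within the scatter). From the compounds shown here alone, it involves the same swap of named groups, and its true size is unknown. Compound 3 differs from compound 4 only in the arrangement of its stereocentres, which makes it the closest guide, though a single one. A modest fall in this assay is therefore expected, and it may not exceed the scatter, with compound 3 at 1.6 h as the anchor. The expected change is an at least 1.5-fold lower number from compound 2 to compound 4 (0.17 log units; that floor lies within the scatter) in the estimate used here. Compound 4 is estimated at 1.6 h in this measurement. The expected range for compound 4 runs from 0.9 h to 2.8 h on that estimate.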

Compound 4, half-life: > 2.41 h
Compound 4: a limit, no number (the forecaster's own chance of this, stated with the estimate: 15%); middle value at least 1.5-fold (0.17 log units) away from the limit.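

In this assay compound 4 gives > 2.41 h, a limit and not a number. The step is an at least 1.5-fold higher number from compound 3 to compound 4 (0.17 log units; that floor lies within the scatter), so a real gap between this pair is possible but not shown, and any such gap could come from only one source: the fact that compounds 3 and 4 differ only in the configuration as drawn The step from compound 2 to compound 4 cannot be read, so at this position on the aromatic nitrogen, a fall on swapping cyclopropyl for 4-(hydroxymethyl)cyclohexyl is not shown for this configuration, with both compounds sitting at the same limit: the limit of > 2.41 h in this assay, at which 2 of the 4 values shown sit.

From the compounds shown here alone, the true half-lives of compound 2 and compound 4 remain unknown, as does the size of any difference between them. Also open, going by these compounds, is whether the drawn configuration would count for the same ring carrying an amine or a carboxylic acid in place of the hydroxymethyl group.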